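This account rests on a few compounds, and the source may have more. Where it says the series, first, only, none or still open, it means among the compounds named here.

Measured compounds in this series:

Compound 1 `O=C1O[C@H]([C@@H](O)Cn2cc(-c3cccc(O)c3)nn2)C(OCc2ccccc2)=C1OCc1ccccc1` gives 42900 nM in a functional assay on HCT-116 cells (Homo sapiens) for antiproliferative activity, read by MTT assay, with a stated time of 72 h; a higher number here means a weaker inhibitor, a lower number a stronger inhibitor.
Compound 2 `O=C1O[C@H]([C@@H](O)Cn2cc(CNS(=O)(=O)c3ccc(Cl)cc3F)nn2)C(OCc2ccccc2)=C1OCc1ccccc1` gives 21600 nM in this assay.
Compound 3 `O=C1O[C@H]([C@@H](O)Cn2cc(CNS(=O)(=O)c3ccc(F)cc3)nn2)C(OCc2ccccc2)=C1OCc1ccccc1` gives 22900 nM in this assay.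

Compound 3 sits second highest of the three numbers. Its nearest neighbour is compound 2, whose value lies within the scatter of it; the furthest is compound 1, and even that gap stays within the scatter. All three compounds share the same core and differ only in the substituent on the five-membered aromatic ring with 3 nitrogen.

The two single-point steps available both stay within the scatter: a 1.9-fold lower number from compound 1 to compound 3 (0.27 log units; within the scatter) and a 1.1-fold higher number from compound 2 to compound 3 (0.03 log units; within the scatter). Neither change moved the number beyond what repeated measurement would give.

The next compound, compound 4 `COc1ccccc1-c1cn(C[C@H](O)[C@H]2OC(=O)C(OCc3ccccc3)=C2OCc2ccccc2)nn1`, carries the change (2-methoxyphenyl in place of (((4-fluorophenyl)sulfonyl)amino)methyl on an aromatic carbon). Among the measured compounds shown here, the step that bears on it is the one from compound 1 to compound 3, because a 1.9-fold lower number from compound 1 to compound 3 (0.27 log units; within the scatter) shows that swapping an aryl on that aromatic carbon for the sulfonamide-bearing methyl hardly moved the number. Returning to an aryl, here 2-methoxyphenyl, is therefore expected to give a step no larger than the scatter, if anything toward the side of compound 1.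

The expected step is a 1.4-fold higher number from compound 3 to compound 4 (0.15 log units; within the scatter). Compound 4 is estimated at 32000 nM, with a range from 14000 nM to 75000 nM.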

Compound 4, half-maximal inhibitory concentration: > 100000 nM
Compound 4 gave a limit, no number (the forecaster's own chance of this, stated with the estimate: 5%); at least 3.1-fold (0.49 log units) between middle value and limit.
By their numbers in this assay, from the lowest: compounds 2, 3 and 1 (each within the scatter of the next). At a limit, above all of these: compound 4.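

In this assay compound 4 gives a limit and not a number: the limit of > 100000 nM in this assay, at which 1 of the 4 values shown sits. The aromatic carbon of the five-membered ring had so far shown only steps within the scatter, but it does respond to the group it carries, as 2-methoxyphenyl in place of (((4-fluorophenyl)sulfonyl)amino)methyl gives an at least 4.3-fold higher number from compound 3 to compound 4 (0.64 log units; beyond the scatter). An exchange of one aryl group for another also counts here, since 2-methoxyphenyl in place of 3-hydroxyphenyl gives an at least 2.3-fold higher number from compound 1 to compound 4 (0.36 log units; beyond the scatter), so an aryl group on this carbon does not by itself fix the number.

As far as these compounds go, both steps are bounds, so their full size stays open, and the step from 3-hydroxyphenyl to 2-methoxyphenyl changes both the oxygen substituent and its place on the phenyl ring, leaving the two effects unseparated. Also open, from the compounds shown here alone, are 2-hydroxyphenyl and 3-methoxyphenyl, which would separate those two changes, and how this position responds to a group of another kind, such as an aliphatic amine or a carboxylic acid.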